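The compounds below may be only part of what the source reports. "The series", "measured", "known", "first", "only" and "open" are said of these compounds alone.

Compound 1 `O=S(=O)(Nc1ccc(-c2nc3ccccc3o2)cc1)c1ccc(Cl)s1` stands at > 100000 nM in an ADME assay on HEK293 cells (Homo sapiens) for cytotoxicity, read by resazurin assay, with a stated time of 48 h (a higher number here means that more compound is tolerated, a lower number that less compound is tolerated), and that value is a limit of the assay, not a number. For the measured compounds named here, compound 2 `O=S(=O)(Nc1ccc2oc(-c3ccccc3)nc2c1)c1ccccc1F` reads 72000 nM in this assay as the only actual number so far. Compound 3 `O=S(=O)(Nc1ccc(-c2nc3ccccc3o2)cc1)c1cccs1` has hydrogen in place of chloro on an aromatic carbon next to the ring sulfur, 5-chlorothiophen-2-yl going to thiophen-2-yl (hydrogen in place of chloro on an aromatic carbon). Going by the values given here, no measured step covers this change, so the expected step (a number no higher from compound 1 to compound 3 (the limit leaves the size open)) in this assay is none beyond the scatter. For compound 3 the estimate is 100000 nM with an expected range from 50000 nM to 200000 nM and a report as a limit is likely.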

Compound 3, half-maximal cytotoxic concentration: > 100000 nM
Compound 3: no number, only a limit; the forecaster's own chance of this, stated with the estimate: 60%; the middle value sits exactly at the limit.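

No step can be read between compound 1 and compound 3 in this assay, as both values are limits: the limit of > 100000 nM in this assay, at which 2 of the 3 values shown sit.

On these data alone, whether hydrogen in place of chloro on the thiophen-2-yl ring changes tolerance in this assay stays open.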